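Triazolylmethyl spiro-oxindole series: aryl variation on the triazole

A few compounds are considered here, and "the series" means these few. Any claim that something is new, unique, unknown or untested is made for them only; others in the source may bear on it.

Measured so far:
compound 1 `N#CC1=C(N)Oc2c(c3nc4ccccc4nc3c3ccccc23)C12C(=O)N(Cc1cnnn1-c1cccc(Cl)c1)c1ccccc12` — 35200 nM
compound 2 `Cc1ccc(-n2nncc2CN2C(=O)C3(C(C#N)=C(N)Oc4c(N)cc5nc6ccccc6nc5c43)c3ccccc32)cc1C` — > 50000 nM

In an ADME assay on L02 cells (Homo sapiens) for antiproliferative activity, read by MTT assay, with a stated time of 48 h (a lower number here means a stronger inhibitor, a higher number a weaker inhibitor), compound 1 gives 35200 nM. Compound 2 returns only a limit of the assay, > 50000 nM, so no number stands for it; it sits where the limit of > 50000 nM in this assay, at which 1 of the 2 values shown sits, describes, with one of the two values at that limit. Going by the values given here, no single-point step between measured compounds is available in this assay, so the two values can only be read side by side: compound 1 gives a number, compound 2 does not.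

Compound 3 `Cc1cc(C)c(-n2nncc2CN2C(=O)C3(C(C#N)=C(N)Oc4c(N)cc5nc6ccccc6nc5c43)c3ccccc32)c(C)c1` is the next member to be measured. It differs from compound 2 by 2,4,6-trimethylphenyl in place of 3,4-dimethylphenyl on an aromatic nitrogen.

Given that compound 2 already stands at the limit > 50000 nM, compound 3 is expected to stay in the same weak region, with a step that the limit leaves unreadable from compound 2 to compound 3 that is no more than the scatter of the assay. Compound 3 is expected to give 60000 nM in this assay, within a range of 30000 nM to 150000 nM, most likely again reported only as a limit.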

Compound 3, half-maximal inhibitory concentration: > 50000 nM
Compound 3 gave a limit, no number (the forecaster's own chance of this, stated with the estimate: 70%); the middle value is on the limit's open side.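

In this assay compound 3 gives only a limit, > 50000 nM. No step can be read from compound 2 to compound 3 because both values are limits: the limit of > 50000 nM in this assay, at which 2 of the 3 values shown sit.

The compounds shown leave open whether 2,4,6-trimethylphenyl and 3,4-dimethylphenyl on the aromatic nitrogen differ at all in this assay.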